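This account rests on a few compounds, and the source may have more. Where it says the series, first, only, none or still open, it means among the compounds named here.

Measured so far in an ADME assay on Caco-2 cells (Homo sapiens) for permeability, read by LC-MS, in the apical to basolateral direction, with a stated time of 2 h, tested at 2 uM; a lower number here means that the compound crosses the layer more slowly, a higher number that the compound crosses the layer faster:
- compound 1 `CCOc1ccccc1-c1ccc(-c2nc3cnccc3c(N[C@H](CC)C(N)=O)c2C#N)cc1`: 151 nm/s
- compound 2 `CC[C@@H](Nc1c(C#N)c(-c2ccc(-c3cccc(Cl)c3)cc2)nc2cnccc12)C(N)=O`: 37 nm/s
- compound 3 `CC[C@@H](Nc1c(C#N)c(-c2ccc(-c3ccc(Cl)cc3)cc2)nc2cnccc12)C(N)=O`: 29 nm/s

Compound 3 stands at 29 nm/s. Compound 2 is level with it, the gap being a 1.3-fold lower number from compound 2 to compound 3 (0.11 log units; within the scatter). Compound 1 stands clearly higher, the gap being a 5.2-fold lower number from compound 1 to compound 3 (0.72 log units; beyond the scatter).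

The next step leads to compound 4 `CC[C@@H](Nc1c(C#N)c(-c2ccc(-c3cccc(OC)c3)cc2)nc2cnccc12)C(N)=O`, with the change (3-methoxyphenyl in place of 4-chlorophenyl on an aromatic carbon). In words, this is 3-methoxyphenyl in place of 4-chlorophenyl on an aromatic carbon, para to a large group.

Among the compounds with values here, no measured compound carries 3-methoxyphenyl, so the evidence is indirect. Exchanging 3-chlorophenyl for 4-chlorophenyl gave a 1.3-fold lower number from compound 2 to compound 3 (0.11 log units; within the scatter), which offers no guide to a large effect from the place of the substituent. The only measured ring with an ether group is the 2-ethoxyphenyl of compound 1, and replacing it gave a 4.1-fold lower number from compound 1 to compound 2 (0.61 log units; beyond the scatter) and a 5.2-fold lower number from compound 1 to compound 3 (0.72 log units; beyond the scatter), both modest. This single example points weakly upward for compound 4 in this assay, with a small rise expected that need not clear the scatter. The expected move is a 1.7-fold higher number from compound 3 to compound 4 (0.24 log units; within the scatter). Compound 4 is estimated at 50 nm/s, with an expected range from 22 nm/s to 120 nm/s.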

Compound 4, apparent permeability: 104 nm/s
Compound 4: the middle estimate sits 2.1-fold (0.32 log units) below what was measured; measured number inside the range.
By their numbers in this assay, from the lowest: compounds 3 and 2 (each within the scatter of the next); then compounds 4 and 1 (each within the scatter of the next).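

In this assay, the ring para to a large group is now seen to respond to its substituent and not only to the change away from the 2-ethoxyphenyl of compound 1: 3-methoxyphenyl in place of 4-chlorophenyl gives a 3.6-fold higher number from compound 3 to compound 4 (0.55 log units; beyond the scatter), and methoxy in place of chloro, with the rest of the structure held, gives a 2.8-fold higher number from compound 2 to compound 4 (0.45 log units; beyond the scatter). The 2-ethoxyphenyl is also no longer the only group linked to the upper level, as 3-methoxyphenyl in place of it gives a 1.5-fold lower number from compound 1 to compound 4 (0.16 log units; within the scatter), so among these four compounds the two ether-bearing rings stand above the two chloro rings, with no compound going against this. No measurement shown here accounts for this separation.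

As far as these compounds go, whether a 3-methylphenyl, with carbon in place of the ether oxygen, or a 3-aminophenyl would stand with the ether rings or with the chloro rings remains open. Also open, from the compounds shown here alone, is whether 4-methoxyphenyl would stand level with 3-methoxyphenyl, as the two chloro rings do in a 1.3-fold lower number from compound 2 to compound 3 (0.11 log units; within the scatter), or whether a longer ether chain at either place would hold the same level.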